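The source may report more compounds than this note shows. Statements on the series, on what has been measured and on what is new or still open speak of the compounds shown alone.

Compound 1 `CC(C)(C)c1ccc(CNCCNS(=O)(=O)c2cc(C(F)(F)F)cc(C(F)(F)F)c2)cc1`: 14000 nM in a functional assay on A2780 cells (Homo sapiens) for inhibition, read by MTT assay, with a stated time of 72 h; on this read-out lower numbers stand for stronger inhibition of growth and higher numbers for weaker inhibition of growth
Compound 2 `O=S(=O)(NCCNCc1ccc(-c2ccccc2)cc1)c1cc(C(F)(F)F)cc(C(F)(F)F)c1`: 2600 nM
Compound 3 `O=S(=O)(NCCCNCc1ccc(C(F)(F)F)cc1)c1cc(C(F)(F)F)cc(C(F)(F)F)c1`: 2800 nM

Among these three numbers compound 3 stands second highest. Its nearest neighbour is compound 2, whose value lies within the usual scatter of compound 3, so the two cannot be told apart. Its furthest neighbour is compound 1, whose higher number stands beyond the scatter, marking weaker inhibition of growth.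

Compound 4 `O=S(=O)(NCCCNCc1ccc(Br)cc1)c1cc(C(F)(F)F)cc(C(F)(F)F)c1` has not yet been measured. It differs from compound 3 in one place: bromo in place of trifluoromethyl on an aromatic carbon.

Within the data shown here, only one step among the measured compounds is known, a 5.4-fold lower number from compound 1 to compound 2 (0.73 log units; beyond the scatter), and that step changes a different group at a different place in the molecule, so it does not speak to the present change. There is thus no measured guide for swapping bromo for trifluoromethyl here, and the plain expectation is a step of no more than the usual scatter in either direction.

Compound 4 is therefore estimated at 2800 nM, with a range from 1000 nM to 8000 nM, which means an expected step of no change at the digits printed from compound 3 to compound 4 (within the scatter).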

Compound 4, concentration for 50% growth inhibition: 2600 nM
Estimate against measurement, compound 4: 1.1-fold (0.03 log units) above; the range from low to high includes it.
By their numbers in this assay, from the lowest: compounds 2, 4 and 3 (each within the scatter of the next); then compound 1.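

Going from the 4-(trifluoromethyl)benzyl group to the 4-bromobenzyl group gives a 1.1-fold lower number from compound 3 to compound 4 (0.03 log units; within the scatter) in this assay, so the two compounds cannot be told apart. Among these compounds, this is the first measured change at this place on the aromatic ring. For this pair, a group of 4 heavy atoms and a single bromine atom leave the read-out unchanged within the scatter. No measurement of any property of the two groups is at hand to account for this match.

As far as these compounds go, it remains open whether a methoxy group, an amine or a carboxylic acid at this place would also match compound 3 or would move the number beyond the scatter. From the compounds shown here alone, it is also open whether the same swap would give the same result on a longer chain.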